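The source may hold more compounds than are shown below. What is called first, only, known or untested is meant among the compounds shown, and "the series" means these compounds.

Measured compounds:
Compound 1 `CCC1=C(O)c2c(oc(-c3ccc(COC)cc3)cc2=O)C(CC)(CC)C1=O`: 3.4 uM
Compound 2 `CCC1=C(O)c2c(oc(-c3ccccc3F)cc2=O)C(CC)(CC)C1=O`: 3.93 uM
Compound 3 `CCC1=C(O)c2c(oc(-c3ccc(C)c(C)c3)cc2=O)C(CC)(CC)C1=O`: 0.71 uM

All three share one core and differ only in the aromatic group attached to it. In a functional assay on KBVIN cells (Homo sapiens) for antiproliferative activity, read by sulforhodamine B assay, with a stated time of 3 days (on this read-out higher numbers stand for an effect only at larger amounts of compound and lower numbers for an effect already at smaller amounts), compound 3 gives 0.71 uM, the lowest of the three numbers; the steps of a 4.8-fold lower number from compound 1 to compound 3 (0.68 log units; beyond the scatter) and a 5.5-fold lower number from compound 2 to compound 3 (0.74 log units; beyond the scatter) both lie beyond the scatter, while a 1.2-fold higher number from compound 1 to compound 2 (0.06 log units; within the scatter) does not.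

Compound 4 `CCC1=C(O)c2c(oc(-c3cc(C)c(O)c(C)c3)cc2=O)C(CC)(CC)C1=O` has not yet been tested. It differs from compound 3 only in the aromatic group: 4-hydroxy-3,5-dimethylphenyl in place of 3,4-dimethylphenyl on an aromatic carbon. The ring keeps two methyl groups and gains one oxygen, a single hydrogen-bond donor and acceptor, where compound 3 has none.

Going by the values given here, no measured step introduces a hydroxy group, so nothing here speaks directly to this change. The steps that do exist show that swapping one substituted phenyl ring for another moved the number by modest amounts, a 4.8-fold lower number from compound 1 to compound 3 (0.68 log units; beyond the scatter) and a 5.5-fold lower number from compound 2 to compound 3 (0.74 log units; beyond the scatter), so a shift of similar size in either direction is plausible. Among the compounds with values here, with no closer precedent, the expected step of a 2.1-fold higher number from compound 3 to compound 4 (0.32 log units; beyond the scatter) is a small loss, since compound 3 already holds the lowest number. Compound 4 is therefore estimated at 1.5 uM, with a range from 0.4 uM to 6 uM in this assay.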

Compound 4, concentration for half-maximal effect: 8.9 uM
Compound 4: middle estimate off by 5.9-fold (0.77 log units), on the low side; measured number above the stated range.
By their numbers in this assay, from the lowest: compound 3; then compounds 1 and 2 (each within the scatter of the next); then compound 4.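

In this assay, replacing 3,4-dimethylphenyl with 4-hydroxy-3,5-dimethylphenyl gives a 13-fold higher number from compound 3 to compound 4 (1.10 log units; beyond the scatter), the largest step among these compounds, so this position responds more strongly to this change than to any of the ring swaps seen before. The new ring also compares poorly with the other two groups, giving a 2.3-fold higher number from compound 2 to compound 4 (0.35 log units; beyond the scatter) and a 2.6-fold higher number from compound 1 to compound 4 (0.42 log units; beyond the scatter), which leaves compound 4 with the highest number of the four and shows that having two methyl groups on the ring does not by itself secure the low number of compound 3. No outside measurement is available here to explain this rise.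

The change does two things at once, adding a hydroxy group and altering the methyl pattern of 3,4-dimethylphenyl to that of 4-hydroxy-3,5-dimethylphenyl, and the compounds shown cannot separate these two contributions. A plain 3,5-dimethylphenyl ring would isolate the effect of the methyl pattern, while a 4-methoxy-3,5-dimethylphenyl ring, or an amine in place of the hydroxy group, would show whether the rise depends on that hydroxy group or appears with other groups at the same spot.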